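A longer amine substituent on the shared core

The source may report more compounds than this note shows. Statements on the series, on what has been measured and on what is new or still open speak of the compounds shown alone.

Of the compounds shown here, two have been measured so far. Compound 1 `CNCc1c(OC)cc(Oc2cccc(Nc3ccccc3)c2)cc1OC` gives 8930 nM in a functional assay on HCT-15 cells (Homo sapiens) for inhibition, read by MTT assay, with a stated time of 72 h (a lower number here means a stronger inhibitor, a higher number a weaker inhibitor), the higher of the two numbers. Among the compounds with values here, compound 2 `COc1ccc([C@@H](C)NCc2c(OC)cc(Oc3cccc(Nc4ccccc4)c3)c(OC)c2OC)cc1` gives 4690 nM in this assay; the gap between these two values lies within the usual scatter, and compound 2 differs from compound 1 in more than one place, so no single step is drawn between them.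

Compound 3 `COc1ccc(CCCNCc2c(OC)cc(Oc3cccc(Nc4ccccc4)c3)cc2OC)cc1` has not yet been measured. It differs from compound 1 by 2-(4-methoxyphenyl)ethyl in place of hydrogen on a saturated chain carbon bound to an amine nitrogen, so that methylamino becomes (3-(4-methoxyphenyl)propyl)amino. Within the data shown here, the data give no measured step for this kind of change. A modest move toward a lower number is expected, as a 1.8-fold lower number from compound 1 to compound 3 (0.25 log units; within the scatter), since nothing beyond the scatter is certain. Compound 3 is therefore estimated at 5000 nM in this assay, with a range from 1800 nM to 14000 nM.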

Compound 3, half-maximal inhibitory concentration: 730 nM
Estimate against measurement, compound 3: 6.8-fold (0.84 log units) above; the whole stated range lies above it.
By their numbers in this assay, from the lowest: compound 3; then compounds 2 and 1 (each within the scatter of the next).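

Changing methylamino to (3-(4-methoxyphenyl)propyl)amino on the shared core brings a 12-fold lower number from compound 1 to compound 3 (1.09 log units; beyond the scatter) in this assay. Within the data shown here, this is the first clear sign that the number responds to the group on this amine nitrogen, as compound 1 and compound 2 differ in more than one place and their values lie within the scatter of each other. Nothing available explains why this longer substituent goes with the lower number.

With a single long substituent shown, the roles of the chain and of the methoxy group on its ring cannot be told apart. From the compounds shown here alone, whether a plain 3-phenylpropyl group, a shorter 2-phenylethyl group or a still longer chain ending in 4-methoxyphenyl would give a similar number remains open.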